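Amide to Sulfonamide: Compound 3 Estimated from Compound 2

The compounds below may be only part of what the source reports. "The series", "measured", "known", "first", "only" and "open" are said of these compounds alone.

Compound 2 `COc1ccc(C(=O)Nc2cccc(/C=C/C(=O)c3nc4ccccc4[nH]3)c2)cc1` gives 20100 nM in a functional assay on MCF7 cells (Homo sapiens) for antiproliferative activity, read by MTT assay, with a stated time of 48 h; a lower number here means a stronger inhibitor, a higher number a weaker inhibitor. Going by the values given here, only one other compound has been measured: compound 1 `COc1cccc(C(=O)Nc2cccc(/C=C/C(=O)c3nc4ccccc4[nH]3)c2)c1` gives 17800 nM in this assay, and the step of a 1.1-fold higher number from compound 1 to compound 2 (0.05 log units; within the scatter), which exchanges 3-methoxyphenyl for 4-methoxyphenyl on a carbonyl carbon, falls within the scatter, so the two compounds stand side by side rather than apart. Compound 3 `O=C(/C=C/c1cccc(NS(=O)(=O)c2ccc(Cl)cc2)c1)c1nc2ccccc2[nH]1` differs from compound 2 in one place: (4-chlorophenyl)sulfonyl in place of (4-methoxyphenyl)carbonyl on a nitrogen on an aromatic ring. Among the compounds with values here, no measured step bears on a change of this kind; the single step in hand only moves a methoxy group around a ring and keeps the carbonyl, so it offers no precedent for a sulfonyl or a chlorine. With nothing to point either way, the step of a 1.1-fold lower number from compound 2 to compound 3 (0.05 log units; within the scatter) is estimated to stay within the scatter, in no particular direction. Compound 3 is therefore expected near 18000 nM, with a broad range from 5000 nM to 60000 nM.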

Compound 3, half-maximal inhibitory concentration: 3820 nM
The estimate for compound 3 lay 4.7-fold (0.67 log units) above the measured number, and the stated range ends above it.
By their numbers in this assay, from the lowest: compound 3; then compounds 1 and 2 (each within the scatter of the next).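

In this assay, the group on the nitrogen on an aromatic ring turns out to matter, where moving the methoxy group had shown no change beyond the scatter: (4-chlorophenyl)sulfonyl in place of (4-methoxyphenyl)carbonyl gives a 5.3-fold lower number from compound 2 to compound 3 (0.72 log units; beyond the scatter) in this series. Set against the other methoxy compound, the same kind of exchange gives a 4.7-fold lower number from compound 1 to compound 3 (0.67 log units; beyond the scatter) and so does not depend on which of the two methoxyphenyl amides serves as the starting point. Nothing in the data shown gives a reason for either step.

The compounds shown leave open how much of the step belongs to the sulfonyl and how much to the chlorine: the two enter together, and neither 4-chlorophenyl on a carbonyl nor 4-methoxyphenyl on a sulfonyl appears here. Also open, from the compounds shown here alone, is how a ring bearing an amine or a carboxylic acid would fare on the sulfonyl.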